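Fluoro for the diamine side chain on the core

A few compounds are considered here, and "the series" means these few. Any claim that something is new, unique, unknown or untested is made for them only; others in the source may bear on it.

Compound 1 `COc1ccc2c(c1)CC(c1nc3c(N(C)CCN(C)C)cc(-c4cn[nH]c4)cc3c(=O)[nH]1)CO2` stands highest of the three numbers measured in an assay on isolated protein for inhibition of Rho-associated protein kinase 2 (Homo sapiens), read by HTRF (on this read-out lower numbers stand for stronger inhibition and higher numbers for weaker inhibition), where compound 1 gives 21 nM. The nearest is compound 2 `Cc1ccc2c(c1)CC(c1nc3ccc(-c4cn[nH]c4)cc3c(=O)[nH]1)CO2`, which in this assay gives 6 nM; the furthest is compound 3 `O=c1[nH]c(C2COc3ccc(F)cc3C2)nc2ccc(-c3cn[nH]c3)cc12`, which gives 3 nM. Within the data shown here, the one measured step, a 2.0-fold lower number from compound 2 to compound 3 (0.30 log units; within the scatter), lies on the other ring of the core and stays within the scatter.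

Compound 4 `COc1ccc2c(c1)CC(c1nc3c(F)cc(-c4cn[nH]c4)cc3c(=O)[nH]1)CO2` differs from compound 1 by fluoro in place of (2-(dimethylamino)ethyl)(methyl)amino on an aromatic carbon. Among the measured compounds shown here, no measured step bears directly on this change: compounds 2 and 3 carry hydrogen at that carbon and also differ from compound 1 on the other ring, so their lower numbers cannot be split between the two sites. For the measured compounds named here, the values of compounds 2 and 3 show only that a small group at this carbon is compatible with strong inhibition. A moderate move toward those numbers is therefore expected, of the size a 2.6-fold lower number from compound 1 to compound 4 (0.42 log units; beyond the scatter). Compound 4 is estimated at 8 nM in this assay, with a range from 3 nM to 25 nM.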

Compound 4, half-maximal inhibitory concentration: 104 nM
The estimate for compound 4 lay 13-fold (1.11 log units) below the measured number; the measured number lies above the stated range.
By their numbers in this assay, from the lowest: compounds 3 and 2 (each within the scatter of the next); then compound 1; then compound 4.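

At this aromatic carbon, with the rest of the structure unchanged, fluoro in place of (2-(dimethylamino)ethyl)(methyl)amino gives a 5.0-fold higher number from compound 1 to compound 4 (0.69 log units; beyond the scatter) in this assay, so the long chain is tolerated better here than the single fluorine. Among these compounds, the low numbers of compound 2 and compound 3 therefore do not carry over to fluoro at this carbon, although both compounds differ from compound 4 in two places and no step links them to it. Nothing available explains the step.

As far as these compounds go, it remains open whether the chain adds to inhibition or fluoro takes away from it, as neither compound 1 nor compound 4 has a partner with hydrogen at this carbon and an otherwise identical structure. A shorter amine such as dimethylamino at the same carbon would show how much of the chain is needed.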